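Dibenzyl-type ureas: aryl swap from compound 3 to compound 4

This account rests on a few compounds, and the source may have more. Where it says the series, first, only, none or still open, it means among the compounds named here.

Compound 3 `CCOc1ccc(NC(=O)N(Cc2ccccc2)Cc2ccccc2)cc1` gives 3.47 ug/mL in an assay on isolated protein for inhibition of sterol O-acyltransferase 1 (Rattus norvegicus); a lower number here means a stronger inhibitor, a higher number a weaker inhibitor. It stands second highest of the three numbers: compound 1 `CCCCN(CCCC)C(=O)Nc1cccc(Cl)c1C` gives 1.21 ug/mL, a lower number beyond the scatter, and compound 2 `CCCCN(CCCC)C(=O)Nc1ccc(F)c(Cl)c1` gives 343 ug/mL, a far higher number beyond the scatter. Compound 4 `O=C(Nc1cccc(Cl)c1)N(Cc1ccccc1)Cc1ccccc1` differs from compound 3 by 3-chlorophenyl in place of 4-ethoxyphenyl on an amide-type nitrogen. Within the data shown here, no measured pair shows this single change, and compounds 1 and 2 differ from compound 3 in more than one place, so they give no direct guide. For compound 4 the expected step in this assay is a 1.4-fold higher number from compound 3 to compound 4 (0.16 log units; within the scatter), a small move toward a higher number or none beyond the scatter. Compound 4 is therefore estimated at 5 ug/mL, within 1.2 ug/mL to 25 ug/mL.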

Compound 4, half-maximal inhibitory concentration: 2.72 ug/mL
Compound 4: the middle estimate sits 1.8-fold (0.26 log units) above what was measured; the measured number falls inside the stated range.
By their numbers in this assay, from the lowest: compound 1; then compounds 4 and 3 (each within the scatter of the next); then compound 2.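

In this assay, 3-chlorophenyl in place of 4-ethoxyphenyl on the amide-type nitrogen gives the first step measured at this position (a 1.3-fold lower number from compound 3 to compound 4 (0.11 log units; within the scatter)). In this pair, the dibenzyl-type urea keeps its reading with the ethoxy group and its counted hydrogen-bond acceptor gone and a chlorine on the ring instead. No supporting data explain this result.

One pair cannot show whether the ring's substituent matters at all in this series. Still open, on these data alone, is how a carboxylic acid or an amine on the phenyl ring would read.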